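The source may hold more compounds than are shown below. What is called first, only, known or untested is meant among the compounds shown, and "the series" means these compounds.

Measured in a functional assay on CHO cells for agonist activity at sphingosine 1-phosphate receptor 2 (Homo sapiens), read by fluorescence and calcium flux, with a stated time of 3 min; on this read-out lower numbers stand for stronger inhibition and higher numbers for weaker inhibition:
compound 1, `Cc1cc(C#N)nc(NNC(=O)Nc2cc(Cl)nc(Cl)c2)c1`, gives > 23000 nM, a limit of the assay.
compound 2, `Cc1cc(NNC(=O)Nc2cc(Cl)nc(Cl)c2)nc(-c2cnn(C)c2)c1`, gives > 23000 nM, a limit of the assay.
compound 3, `Cc1cc(NNC(=O)Nc2cc(Cl)nc(Cl)c2)nc(C(=O)NC2CC2)c1`, gives > 23000 nM, a limit of the assay.

The three compounds share one core and differ only in the group on an aromatic carbon. The steps between them, a step that the two limits leave unreadable from compound 1 to compound 2, a step that the two limits leave unreadable from compound 1 to compound 3 and a step that the two limits leave unreadable from compound 2 to compound 3, stay unreadable because of the limit of > 23000 nM in this assay, at which 3 of the 3 values shown sit. Compound 3 therefore stands at that limit in this assay without a number of its own, and the two further values are limits as well, so nothing separates compound 3 from the others on the numbers shown.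

Compound 4, `Cc1cc(NNC(=O)Nc2cc(Cl)nc(Cl)c2)nc(C(=O)N(C)C2CC2)c1`, differs from compound 3 by methyl in place of hydrogen on an amide-type nitrogen. For the measured compounds named here, no measured step is readable, so none gives a size or a direction for this change; what the series offers is the limit of > 23000 nM in this assay, at which 3 of the 3 values shown sit. For compound 4 the expected outcome in this assay is accordingly another limit rather than a number, the step from compound 3 to compound 4 being estimated at a number no higher from compound 3 to compound 4 (the limit leaves the size open). Compound 4 is estimated at 23000 nM, with a range from 6000 nM to 90000 nM.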

Compound 4, half-maximal inhibitory concentration: > 23000 nM
Compound 4: only a limit was reported; the forecaster's own chance of this, stated with the estimate: 85%; the middle value sits exactly at the limit.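

In this assay compound 4 is again a limit of the assay, and no step linking it to compound 1, compound 2 or compound 3 can be read: the limit of > 23000 nM in this assay, at which 4 of the 4 values shown sit.

The compounds shown leave open whether methyl in place of hydrogen on the amide-type nitrogen, or any other change among them, moves the value, and in which direction.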